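The source may report more compounds than this note shows. Statements on the series, on what has been measured and on what is new or still open speak of the compounds shown alone.

Series on the shared core of compound 1 `O=C(CSc1nnc(-c2ccncc2)n1-c1ccccc1)N/N=C/c1ccc([N+](=O)[O-])cc1`, which in a functional assay on MCF7 cells (Homo sapiens) for inhibition, read by MTT assay, with a stated time of 48 h (on this read-out lower numbers stand for stronger inhibition and higher numbers for weaker inhibition), gives 15300 nM. Compound 2 `O=C(CSc1nnc(-c2ccncc2)n1-c1ccccc1)N/N=C/c1ccc(O)cc1` carries hydroxy in place of nitro on an aromatic carbon. In this assay compound 2 reaches only a limit of the assay, > 50000 nM, and no number. For the measured compounds named here, the one measured step, an at least 3.2-fold higher number from compound 1 to compound 2 (0.51 log units; beyond the scatter), is therefore known only as a bound on its size, set by the limit of > 50000 nM in this assay, at which 1 of the 2 values shown sits. Compound 2 thus stands at the weak end of the two numbers shown, without a value of its own beyond that limit.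

Compound 3 `O=C(CSc1nnc(-c2ccncc2)n1-c1ccccc1)N/N=C/c1ccc(Cl)cc1` is not yet measured. Its difference from compound 2: chloro in place of hydroxy on an aromatic carbon, that is 4-hydroxyphenyl to 4-chlorophenyl. Going by the values given here, the only step bearing on this change is an at least 3.2-fold higher number from compound 1 to compound 2 (0.51 log units; beyond the scatter), which moved the read-out toward weaker inhibition. Chloro in place of hydroxy takes out the group introduced in that step, so a move back toward the number of compound 1 is the working expectation, though its size cannot be fixed while compound 2 sits at a limit. In this assay compound 3 is expected at 20000 nM, with a range of 8000 nM to 60000 nM. The expected step is an at least 2.5-fold lower number from compound 2 to compound 3 (0.39 log units; beyond the scatter).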

Compound 3, half-maximal inhibitory concentration: 9930 nM
Beside the measured number, compound 3's estimate is 2.0-fold (0.30 log units) above it; low and high end bracket the measured number.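

The 4-chlorophenyl of compound 3 shows that the loss seen with hydroxy does not extend to every replacement of nitro on this aromatic carbon, para to a large group: in this assay, chloro in place of nitro gives a 1.5-fold lower number from compound 1 to compound 3 (0.19 log units; within the scatter), so the two groups cannot be told apart on this read-out. Hydroxy is therefore the group that stands apart among the three shown, and replacing it with chloro gives an at least 5.0-fold lower number from compound 2 to compound 3 (0.70 log units; beyond the scatter), a step known only as a bound on its size: the limit of > 50000 nM in this assay, at which 1 of the 3 values shown sits.

The exchange also removes a hydrogen-bond donor and a hydrogen-bond acceptor, but this remains a structural difference, and nothing measured here links it to the read-out.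

From the compounds shown here alone, it remains open whether an amine or a carboxylic acid on this carbon would fall with hydroxy or with nitro and chloro, and whether methoxy, which keeps the oxygen of hydroxy but not its hydrogen, would restore the number. Also open, going by these compounds, is whether any group at this position can move the number beyond the scatter from that of compound 1.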